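The source may hold more compounds than are shown below. What is called first, only, known or untested is meant among the compounds shown, and "the series" means these compounds.

Of the compounds shown here, two have been measured in an ADME assay on L02 cells (Homo sapiens) for antiproliferative activity, read by MTT assay, with a stated time of 48 h; on this read-out lower numbers stand for stronger inhibition and higher numbers for weaker inhibition. Compound 1, `N#CC1=C(N)Oc2c(c3nc4ccccc4nc3c3ccccc23)C12C(=O)N(Cc1cnnn1-c1ccc(F)c(Cl)c1)c1ccccc12`, returns only the assay limit: in this assay compound 1 gives > 50000 nM. Compound 2, `COc1ccc(-n2nncc2CN2C(=O)C3(C(C#N)=C(N)Oc4c(N)cc5nc6ccccc6nc5c43)c3ccccc32)cc1`, likewise returns only a limit, and in this assay compound 2 gives > 50000 nM. Compound 2 therefore stands at the limit of > 50000 nM in this assay, at which 2 of the 2 values shown sit, so no number, only a limit, is available for it. Compound 3, `N#CC1=C(N)Oc2c(N)cc3nc4ccccc4nc3c2C12C(=O)N(Cc1cnnn1-c1ccc([N+](=O)[O-])cc1[N+](=O)[O-])c1ccccc12`, has not yet been measured. It differs from compound 2 by 2,4-dinitrophenyl in place of 4-methoxyphenyl on an aromatic nitrogen. No step between measured compounds is known, so there is no measured basis for expecting a change in either direction; the two limits shown point to no step beyond the scatter. The step that the estimate below means, a number no higher from compound 2 to compound 3 (the limit leaves the size open), is expected to be none beyond the scatter. Compound 3 is estimated at 50000 nM, within a range from 20000 nM to 100000 nM, and is expected most likely to return only a limit again.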

Compound 3, half-maximal inhibitory concentration: 22800 nM
Compound 3: middle estimate off by 2.2-fold (0.34 log units), on the high side; low and high end bracket the measured number.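

In this assay, the group on the aromatic nitrogen of the five-membered ring proves able to shift the read-out: 2,4-dinitrophenyl in place of 4-methoxyphenyl gives an at least 2.1-fold lower number from compound 2 to compound 3 (0.34 log units; beyond the scatter). Among the compounds shown here, this is the first step that can be read, and it lies beyond the scatter, with compound 3 giving a number where the earlier compounds gave only limits. The true size of the step stays open because compound 2 gives only a limit: the limit of > 50000 nM in this assay, at which 2 of the 3 values shown sit.

The compounds shown leave open whether the step needs both nitro groups or would appear with a single nitro group, and whether a plain phenyl or an aminophenyl group at this position would also give a number. They also give no cause for the step.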